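Title: One substituent swap carried onto a second core

The source may report more compounds than this note shows. Statements on the series, on what has been measured and on what is new or still open speak of the compounds shown alone.

Compound 1 `Cc1cc(=O)n(-c2cccc(F)c2)nc1C(=O)Nc1ccc(Oc2ncnc3[nH]ccc23)c(F)c1` and compound 2 `Cc1ccc(-n2nc(C(=O)Nc3ccc(Oc4ncnc5[nH]ccc45)c(F)c3)c(C)cc2=O)cc1` share one core. In a functional assay on MCF7 cells (Homo sapiens) for cytotoxicity, read by MTT assay, with a stated time of 72 h (on this read-out higher numbers stand for weaker inhibition and lower numbers for stronger inhibition), compound 1 gives 32000 nM, and compound 2 gives 18900 nM; the change 4-methylphenyl in place of 3-fluorophenyl on an aromatic nitrogen made a 1.7-fold lower number from compound 1 to compound 2 (0.23 log units; within the scatter). Compound 3 `Cc1cc(=O)n(-c2cccc(F)c2)nc1C(=O)Nc1ccc(Oc2ncnc3c2ccn3C)cc1` stands on a second core; how its core differs from that of compound 1 is not broken down here. In this assay compound 3 gives 30800 nM. Compound 4 `Cc1ccc(-n2nc(C(=O)Nc3ccc(Oc4ncnc5c4ccn5C)cc3)c(C)cc2=O)cc1` carries the same change, (4-methylphenyl in place of 3-fluorophenyl on an aromatic nitrogen), onto the core of compound 3, and the surroundings of the place are the same in both pairs. The step from compound 3 to compound 4 is expected to be of similar size, a 1.5-fold lower number from compound 3 to compound 4 (0.19 log units; within the scatter), because the first pair showed a 1.7-fold lower number from compound 1 to compound 2 (0.23 log units; within the scatter). For compound 4 the estimate in this assay is 20000 nM, between 9000 nM and 45000 nM.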

Compound 4, half-maximal inhibitory concentration: 10800 nM
Beside the measured number, compound 4's estimate is 1.9-fold (0.27 log units) above it; the measured number falls inside the stated range.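

In this assay, 4-methylphenyl in place of 3-fluorophenyl on an aromatic nitrogen gave a 2.9-fold lower number from compound 3 to compound 4 (0.46 log units; beyond the scatter) on the second core. The change lowers the number on both cores, and the two steps do not differ by more than the scatter: the same change on two cores in this assay, a 1.7-fold lower number (0.23 log units; within the scatter) from compound 1 to compound 2 and a 2.9-fold lower number (0.46 log units; beyond the scatter) from compound 3 to compound 4, 1.7-fold (0.23 log units) apart, within the scatter of two such steps. This fits a change that carries from one core to the other, but the step on the first core lies within the scatter on its own, and two cores show neither how general the effect is nor why it arises.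

Open, as far as these compounds go, is whether a plain phenyl, or a phenyl bearing an amine or a carboxylic acid, on the same aromatic nitrogen would follow the same course on both cores. Also open, from the compounds shown here alone, is whether the step would hold on a third core.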